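Swapping Fluoro for Bromo on the Aromatic Carbon

A few compounds are considered here, and "the series" means these few. Any claim that something is new, unique, unknown or untested is made for them only; others in the source may bear on it.

Compound 1 `COc1cccc(/C=C/C(=O)c2c(OC)cc(OC)cc2OC)c1` gives 4300 nM
Compound 2 `COc1cc(OC)c(C(=O)/C=C/c2ccc(F)cc2)c(OC)c1` gives 6200 nM

Both numbers come from a functional assay on HCT-116 cells (Homo sapiens) for cytotoxicity, with a stated time of 48 h; a lower number here means a stronger inhibitor, a higher number a weaker inhibitor. Among the compounds with values here, with only these two values, compound 2 cannot be separated from compound 1, since the single measured step is a 1.4-fold higher number from compound 1 to compound 2 (0.16 log units; within the scatter).

The next compound, compound 3 `COc1cc(OC)c(C(=O)/C=C/c2ccc(Br)cc2)c(OC)c1`, has not yet been measured. It differs from compound 2 in one place: bromo in place of fluoro on an aromatic carbon. Put simply, this is bromo in place of fluoro on an aromatic carbon, so 4-fluorophenyl becomes 4-bromophenyl.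

Within the data shown here, only one measured step bears on this change. Going to compound 2 replaced 3-methoxyphenyl with 4-fluorophenyl, the same part of the molecule, and that larger swap gave only a 1.4-fold higher number from compound 1 to compound 2 (0.16 log units; within the scatter). Among the measured compounds shown here, no measured compound carries bromo, so the evidence is thin, and a small change is the reasonable expectation in this assay, with no direction favoured.

The expected move is a 1.2-fold lower number from compound 2 to compound 3 (0.09 log units; within the scatter), which would not stand beyond the scatter. For compound 3 the estimated value is 5000 nM, with an expected range from 2200 nM to 11000 nM.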

Compound 3, half-maximal inhibitory concentration: 6200 nM
For compound 3 the middle estimate is 1.2-fold (0.09 log units) below the measured one; low and high end bracket the measured number.
By their numbers in this assay, from the lowest: compounds 1, 2 and 3 (each within the scatter of the next).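

In this assay, putting bromo in place of fluoro on this aromatic carbon leaves the number unchanged (no change at the digits printed from compound 2 to compound 3 (within the scatter)), so this assay cannot tell these two halogens apart at this spot on the ring. Within the data shown here, the wider exchange of 3-methoxyphenyl for 4-bromophenyl also stays within the scatter (a 1.4-fold higher number from compound 1 to compound 3 (0.16 log units; within the scatter)), which means that three different aryl groups on the same core now give values that cannot be separated, where before there was only a single pair to compare. Nothing measured here offers an explanation for this flat result.

On these data alone, all three groups compared so far are neutral substituted phenyl rings, so it remains open whether an amine or a carboxylic acid at this same place on the ring would move the number beyond the scatter. As far as these compounds go, it also remains open whether this insensitivity holds elsewhere in the molecule, for example if a longer chain took the place of the two double-bonded chain carbons that link the aryl group to the carbonyl.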